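This account rests on a few compounds, and the source may have more. Where it says the series, first, only, none or still open, it means among the compounds named here.

Within the data shown here, compound 3 `CN1C(=O)C(c2c(F)cccc2F)N(C)c2nc(Nc3ccc(S(N)(=O)=O)cc3)ncc21` gives 42 nM in an assay on Sf9 cells for inhibition of serine/threonine-protein kinase 4 (Homo sapiens), read by luminescence and ADP-Glo, with a stated time of 1 h, in the presence of a further agent that is not named here (a lower number here means a stronger inhibitor, a higher number a weaker inhibitor), the lowest of the three numbers so far. Compound 1 `CCC1C(=O)N(C)c2cnc(Nc3ccc(S(N)(=O)=O)cc3)nc2N1C` gives 479 nM, and compound 2 `CCCC1C(=O)N(C)c2cnc(Nc3ccc(S(N)(=O)=O)cc3)nc2N1C` gives 206 nM. The two steps leading to compound 3 are an 11-fold lower number from compound 1 to compound 3 (1.06 log units; beyond the scatter) and a 4.9-fold lower number from compound 2 to compound 3 (0.69 log units; beyond the scatter), each exchanging ethyl or propyl on the saturated ring carbon for 2,6-difluorophenyl. Compound 4 `CN1C(=O)C(c2cccs2)N(C)c2nc(Nc3ccc(S(N)(=O)=O)cc3)ncc21` differs from compound 3 in one place: thiophen-2-yl in place of 2,6-difluorophenyl on a saturated ring carbon. Both measured steps concern the exchange of a chain for an aromatic ring on that carbon, and none compares two aromatic rings, so they bear only loosely on this change. Since an aromatic ring stays in place, compound 4 is expected to show a 1.9-fold higher number from compound 3 to compound 4 (0.28 log units; within the scatter). Compound 4 is estimated at 80 nM, with a range from 30 nM to 250 nM.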

Compound 4, half-maximal inhibitory concentration: 88 nM
Beside the measured number, compound 4's estimate is 1.1-fold (0.04 log units) below it, and the stated range covers the measured number.
By their numbers in this assay, from the lowest: compound 3; then compound 4; then compound 2; then compound 1.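

In this assay the saturated ring carbon distinguishes between two aromatic rings: thiophen-2-yl in place of 2,6-difluorophenyl gives a 2.1-fold higher number from compound 3 to compound 4 (0.32 log units; beyond the scatter) in a modest step. Thiophen-2-yl still gives lower numbers than either chain, with a 5.4-fold lower number from compound 1 to compound 4 (0.74 log units; beyond the scatter) against ethyl and a 2.3-fold lower number from compound 2 to compound 4 (0.37 log units; beyond the scatter) against propyl, so the gain over a chain is not confined to 2,6-difluorophenyl. Nothing measured here explains the gap between the two rings. From the compounds shown here alone, whether unsubstituted phenyl or pyridine would match these rings, and how an amine or a carboxylic acid on this carbon would read, remains open.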